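Fluoro to bromo on the ring: a second step

The compounds below may be only part of what the source reports. "The series", "measured", "known", "first", "only" and "open" are said of these compounds alone.

Three measured compounds share one core and differ only in the halogen on the aromatic ring and where it sits. Compound 1 `CCC(=O)N(c1cccc(F)c1)C1CCCC1N(C)C` carries fluoro; in a functional assay on the whole organism for antagonist activity, with Mus musculus as the target (a higher number here means that more compound is needed for the effect, a lower number that less compound is needed), compound 1 gives 0.6 mg/kg. Compound 3 `CCC(=O)N(c1cccc(Br)c1)C1CCCC1N(C)C` replaces that fluoro with bromo, a change of bromo in place of fluoro on an aromatic carbon, and in this assay compound 3 gives 0.1 mg/kg, a step of a 6.0-fold lower number from compound 1 to compound 3 (0.78 log units; beyond the scatter). Compound 2 `CCC(=O)N(c1ccc(F)cc1)C1CCCC1N(C)C` carries fluoro at another place; how the core of compound 2 differs from the core of compound 1 is not broken down here. In this assay compound 2 gives 0.08 mg/kg, and the values of compound 2 and compound 3 lie within the scatter of each other. Compound 4 `CCC(=O)N(c1ccc(Br)cc1)C1CCCC1N(C)C` is not yet measured. Its change from compound 2, (bromo in place of fluoro on an aromatic carbon), is the same kind of change as that from compound 1 to compound 3, but the place differs: meta to a large group in the first, para to a large group in the second. Among the measured compounds shown here, the one earlier step, a 6.0-fold lower number from compound 1 to compound 3 (0.78 log units; beyond the scatter), sits at a different place and starts from a higher value, so for compound 4 a smaller step is expected: a 2.0-fold lower number from compound 2 to compound 4 (0.30 log units; within the scatter). Compound 4 is therefore estimated at 0.04 mg/kg in this assay, between 0.015 mg/kg and 0.12 mg/kg.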

Compound 4, dose for half-maximal effect: 3 mg/kg
Beside the measured number, compound 4's estimate is 75-fold (1.88 log units) below it; the whole stated range lies below it.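

Bromo in place of fluoro, para to a large group, gives a 38-fold higher number from compound 2 to compound 4 (1.57 log units; beyond the scatter) in this assay, so the swap that lowered the number on the core of compound 1 raises it here, and the two steps clearly disagree: the same change on two cores in this assay, a 6.0-fold lower number (0.78 log units; beyond the scatter) from compound 1 to compound 3 and a 38-fold higher number (1.57 log units; beyond the scatter) from compound 2 to compound 4, 230-fold (2.35 log units) apart, beyond the scatter of two such steps.
In this series, then, the result of this change on one core cannot be carried over to the other, not even its direction, and a newcomer should treat a single matched pair as a local fact rather than a rule. What this does not show is why the two steps part ways: two pairs cannot separate the place of the halogen from anything else, and they give no rule for other places on the ring.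

The compounds shown leave open what chloro or methoxy would give para to a large group, and whether either would stay close to compound 2 or fall towards compound 4. Also open, on these data alone, is whether the same swap would behave this way with a longer chain on the carbonyl.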